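This account rests on a few compounds, and the source may have more. Where it says the series, first, only, none or still open, it means among the compounds named here.

Measured so far in a functional assay on PC-3 cells (Homo sapiens) for cytotoxicity, read by MTT assay, with a stated time of 72 h; on this read-out lower numbers stand for stronger inhibition of growth and higher numbers for weaker inhibition of growth:
- compound 1 `CCCOC(=O)Nc1ccc([Se]C#N)cc1`: 47400 nM
- compound 2 `O=C(Nc1ccc([Se][Se]c2ccc(NC(=O)OCc3ccccc3)cc2)cc1)OCc1ccccc1`: 33500 nM

The two numbers for compound 1 and compound 2 sit within the scatter of each other, so neither is separated from the other on this assay. Going by the values given here, no step between compounds differing in one place has been measured.

Compound 3 `N#C[Se]c1ccc(NC(=O)OCc2ccccc2)cc1` is not yet measured. It differs from compound 1 by phenyl in place of ethyl on a saturated chain carbon bound to an oxygen next to a carbonyl group. Among the compounds with values here, as the only comparison, compound 2, which also carries the benzyl carbamate, gives 33500 nM, no step beyond the scatter is expected. In this assay compound 3 is estimated at 36000 nM, with a range from 12000 nM to 100000 nM. The expected step is a 1.3-fold lower number from compound 1 to compound 3 (0.12 log units; within the scatter).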

Compound 3, concentration for total growth inhibition: 27800 nM
Compound 3: middle estimate off by 1.3-fold (0.11 log units), on the high side; the measured number falls inside the stated range.
By their numbers in this assay, from the lowest: compounds 3, 2 and 1 (each within the scatter of the next).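

Going by these compounds alone, the only single-place step in this assay is a 1.7-fold lower number from compound 1 to compound 3 (0.23 log units; within the scatter) and it comes with phenyl in place of ethyl on a saturated chain carbon bound to an oxygen next to a carbonyl group. At this place, then, the swap from the small chain to the aromatic ring does not separate the two compounds. Nothing on hand explains the result.

From the compounds shown here alone, whether an amine, a carboxylic acid or a longer chain at this place would give a step beyond the scatter in this assay remains open.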